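Adding a Second Trifluoromethyl: What to Expect

This account rests on a few compounds, and the source may have more. Where it says the series, first, only, none or still open, it means among the compounds named here.

Compound 1, `Fc1ccccc1Nc1nc2nonc2nc1Nc1cccc(OC(F)(F)F)c1`: 600 nM
Compound 2, `Fc1ccccc1Nc1nc2nonc2nc1Nc1cccc(C(F)(F)F)c1`: < 1000 nM (a limit only)

In an assay on mitochondria from L6 cells (Rattus norvegicus) for activation, with a stated time of 90 min (a lower number here means that less compound is needed, a higher number that more compound is needed for the effect), compound 1 gives 600 nM. For compound 2 the assay reports only a limit, < 1000 nM, and not a number. Compound 2 therefore stands at the threshold (the limit of < 1000 nM in this assay, at which 1 of the 2 values shown sits), and its true value could lie anywhere under it. Going by the values given here, the only measured step, a step that the limit leaves unreadable from compound 1 to compound 2, is hidden by that limit and gives no readable size. Compound 3, `Fc1ccccc1Nc1nc2nonc2nc1Nc1cc(C(F)(F)F)cc(C(F)(F)F)c1`, differs from compound 2 by trifluoromethyl in place of hydrogen on an aromatic carbon. Among the compounds with values here, no measured step bears readably on this change, so nothing in the data points to a shift in one direction or the other. One therefore expects no step beyond the scatter in this assay, and estimates a step that the limit leaves unreadable from compound 2 to compound 3. For compound 3 the expected value is 600 nM, with a range from 150 nM to 2500 nM.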

Compound 3, half-maximal effective concentration: < 370 nM
Compound 3: no number, only a limit (the forecaster's own chance of this, stated with the estimate: 40%); at least 1.6-fold (0.20 log units) between middle value and limit.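

In this assay compound 3 gives < 370 nM, which is a limit and not a number. Going by these compounds alone, compound 2 also has only a limit, so no step between compound 2 and compound 3 can be read. The compounds shown leave open whether the added trifluoromethyl shifts the true value, and in which direction.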